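A fluoro to acetamido change on compound 1

This account rests on a few compounds, and the source may have more. Where it says the series, first, only, none or still open, it means among the compounds named here.

Values in an ADME assay on L02 cells (Homo sapiens) for cytotoxicity, read by MTT assay, with a stated time of 24 h (on this read-out higher numbers stand for weaker inhibition and lower numbers for stronger inhibition), for three compounds
- compound 1 `O=C1/C(=C/c2ccccc2F)CN(S(=O)(=O)c2ccc(F)cc2)C/C1=C\c1ccccc1F` gives 19100 nM
- compound 2 `N#Cc1ccc(/C=C2\CN(S(=O)(=O)c3ccc(F)cc3)C/C(=C\c3ccc(C#N)cc3)C2=O)cc1` gives 18900 nM
- compound 3 `COc1cc(/C=C2\CN(S(=O)(=O)c3ccc(F)cc3)C/C(=C\c3cc(OC)cc(OC)c3)C2=O)cc(OC)c1` gives 19800 nM

Compound 1 stands among these numbers with no separation from the other two, since all three values lie within the scatter of one another. Among the compounds with values here, compound 2 and compound 3 differ from compound 1 at other places on the core, and no measured pair shows what a change at the place in question does.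

Compound 4 `CC(=O)Nc1ccc(S(=O)(=O)N2C/C(=C\c3ccccc3F)C(=O)/C(=C/c3ccccc3F)C2)cc1` keeps the core of compound 1 and carries acetamido in place of fluoro on an aromatic carbon, para to a large group (acetamido in place of fluoro on an aromatic carbon). The expectation therefore rests only on the tight grouping around compound 1 at 19100 nM and stays loose. In this assay the step of a 1.0-fold higher number from compound 1 to compound 4 (0.02 log units; within the scatter) is expected to stay within the scatter, with neither direction favoured. For compound 4 an estimated 20000 nM (range 10000 nM to 40000 nM) is expected.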

Compound 4, half-maximal inhibitory concentration: 11600 nM
The estimate for compound 4 lay 1.7-fold (0.24 log units) above the measured number, and the stated range covers the measured number.
By their numbers in this assay, from the lowest: compounds 4, 2, 1 and 3 (each within the scatter of the next).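

In this assay, within the data shown here, replacing fluoro with acetamido on the aromatic carbon gives a 1.6-fold lower number from compound 1 to compound 4 (0.22 log units; within the scatter), the only step read at this position. It shows that 4-fluorophenyl and 4-acetamidophenyl, which differ in size and in the hydrogen-bond donor and acceptor that acetamido brings, are not separated beyond the scatter on the core of compound 1. Nothing available explains the size of this step.

Going by these compounds, whether an amine or a carboxylic acid at this position, or a longer chain in place of acetamido, would give a step beyond the scatter remains open. Also open, on these data alone, is whether the same exchange would read alike when made on compound 2 or compound 3, which carry other groups elsewhere on the shared core.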